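One Side Chain Changes in a Cell Growth Test

The source may report more compounds than this note shows. Statements on the series, on what has been measured and on what is new or still open speak of the compounds shown alone.

Of the compounds shown here, two have numbers so far. Compound 1 `O=C(Nc1ccc(CN2C(=O)c3ccccc3C2=O)cc1)[C@@H]1C[C@H]1c1cccnc1` reached only a limit in a functional assay on COR-L23 cells (Homo sapiens) for antiproliferative activity, read by CellTiter-Glo, with a stated time of 4 days (a higher number here means a weaker inhibitor, a lower number a stronger inhibitor), at > 10000 nM. Among the measured compounds shown here, compound 2 `CCC(=O)NC(C)(C)c1ccc(NC(=O)[C@H]2C[C@@H]2c2cccnc2)cc1` gives 2310 nM, the only actual measured value, so it is the sole numerical reference point. Compound 3 `COCC(=O)N[C@@H](C)c1ccc(NC(=O)[C@H]2C[C@@H]2c2cccnc2)cc1` differs from compound 2 in a single group on an aromatic carbon, para to a large group: a group of 8 heavy atoms (5 carbon, 1 nitrogen, 2 oxygen; no ring) in place of a group of 8 heavy atoms (6 carbon, 1 nitrogen, 1 oxygen; no ring), on an aromatic carbon. For the measured compounds named here, no measured step shows what such a swap does, so the expected change in this assay is none beyond the scatter, an estimated 1.1-fold higher number from compound 2 to compound 3 (0.03 log units; within the scatter). For compound 3 the expected value is 2500 nM, with an estimated range of 700 nM to 9000 nM.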

Compound 3, half-maximal inhibitory concentration: 111 nM
Compound 3: middle estimate off by 23-fold (1.35 log units), on the high side; measured number below the stated range.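

In this assay the group on this aromatic carbon matters a great deal: replacing one group of 8 heavy atoms with another of 8 heavy atoms gives a 21-fold lower number from compound 2 to compound 3 (1.32 log units; beyond the scatter). Matching heavy-atom counts therefore do not mean matching numbers at this position. Nothing shown explains this step.

Going by these compounds, it remains open which feature of the entering group, its second oxygen or its defined stereocentre, goes with the step. Also open, on these data alone, is how a side chain carrying an amine or a carboxylic acid would read here.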